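This account rests on a few compounds, and the source may have more. Where it says the series, first, only, none or still open, it means among the compounds named here.

Of the compounds shown here, three of a shared core have been tested in a functional assay on CCRF-CEM cells (Homo sapiens) for antiproliferative activity, read by MTT assay, with a stated time of 3 days; on this read-out lower numbers stand for stronger inhibition and higher numbers for weaker inhibition. Compound 1 `CCCCC#Cc1cn(C/C=C\CN2C(=O)c3ccccc3C2=O)c(=O)[nH]c1=O` gives 100000 nM. Compound 2 `CCCCC#Cc1cn(C/C=C/CN2C(=O)c3ccccc3C2=O)c(=O)[nH]c1=O` gives 192000 nM. Compound 3 `CCCCc1ccc(C#Cc2cn(C/C=C\CN3C(=O)c4ccccc4C3=O)c(=O)[nH]c2=O)cc1` gives 23000 nM. Compound 2 therefore stands at the highest of the three numbers: the first step is a 1.9-fold higher number from compound 1 to compound 2 (0.28 log units; within the scatter), which rests on (the fact that compounds 1 and 2 differ only in the configuration as drawn), while the gap from compound 2 to compound 3 is beyond the scatter. Within the data shown here, the only step that clearly moved the number is a 4.3-fold lower number from compound 1 to compound 3 (0.64 log units; beyond the scatter), a modest change that replaced the group on the triple-bonded carbon with a larger one.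

Compound 4 `CCCCCC#Cc1cn(C/C=C/CN2C(=O)c3ccccc3C2=O)c(=O)[nH]c1=O` is not yet measured. It differs from compound 2 in one place: methyl in place of hydrogen on a saturated chain carbon, four bonds along the chain from a triple-bonded carbon. Among the measured compounds shown here, no measured step matches this change. The closest comparison is the replacement of butyl by 4-butylphenyl in a 4.3-fold lower number from compound 1 to compound 3 (0.64 log units; beyond the scatter), a much larger alteration than a single added methyl. The chain extension is therefore expected to shift this assay little, with the number for compound 4 expected to fall from compound 2 by a 1.3-fold lower number from compound 2 to compound 4 (0.11 log units; within the scatter), a step that stays within the scatter. For compound 4 the estimate in this assay is 150000 nM, expected to lie between 60000 nM and 400000 nM.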

Compound 4, half-maximal inhibitory concentration: > 500000 nM
Compound 4 was reported as a limit; the forecaster's own chance of this, stated with the estimate: 25%; at least 3.3-fold (0.52 log units) between middle value and limit.
By their numbers in this assay, from the lowest: compound 3; then compounds 1 and 2 (each within the scatter of the next). At a limit, above all of these: compound 4.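

In this assay compound 4 is reported only as a limit, > 500000 nM. Even so, adding a single methyl on a saturated chain carbon, four bonds along the chain from a triple-bonded carbon, gives an at least 2.6-fold higher number from compound 2 to compound 4 (0.41 log units; beyond the scatter), which shows that the far end of this chain is not a silent place and that one extra carbon there can move the number beyond the scatter. The only earlier step beyond the scatter, a 4.3-fold lower number from compound 1 to compound 3 (0.64 log units; beyond the scatter), went the opposite way when 4-butylphenyl replaced butyl, so among these compounds, making the group on the triple-bonded carbon larger does not push the number in one fixed direction.

Going by these compounds, how far the number really rises stays unknown, since the step rests on a value that is not an exact number: the limit of > 500000 nM in this assay, at which 1 of the 4 values shown sits. Also open, on these data alone, are whether a shorter or still longer chain, or an amine or a carboxylic acid at the chain end, would follow the same course, and whether the added methyl acts the same way with the double bond drawn Z, as in compound 1.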